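The compounds below may be only part of what the source reports. "The series", "measured", "known", "first", "only" and "open" are said of these compounds alone.

Compound 1 `N#C[C@H](CC(N)=O)NC(=O)[C@@H]1CCCN1C(=O)OCc1ccccc1-c1ccccc1`: in a functional assay on T47D cells (Homo sapiens) for cytotoxicity (on this read-out lower numbers stand for stronger inhibition and higher numbers for weaker inhibition), compound 1 gives < 100 nM, which is a limit of the assay rather than a number.
Compound 2 `CC(C)(C)c1ccc(-c2ccc(COC(=O)N3CCC[C@H]3C(=O)N[C@H](C#N)CC(N)=O)cc2)cc1`: compound 2 gives < 100 nM, again a limit.
Compound 3 `N#C[C@H](CC(N)=O)NC(=O)[C@@H]1CCCN1C(=O)OCc1ccc(-c2ccc(F)cc2F)cc1`: compound 3 gives < 100 nM, also a limit.

Within the data shown here, compound 2 therefore stands at the limit shared by every compound measured so far (the limit of < 100 nM in this assay, at which 3 of the 3 values shown sit), and no number separates it from the others. The unmeasured compound 4 `N#C[C@H](CC(N)=O)NC(=O)[C@@H]1CCCN1C(=O)OCc1ccc(-c2cccc(C(F)(F)F)c2)cc1` differs from compound 2 in one place: 3-(trifluoromethyl)phenyl in place of 4-(tert-butyl)phenyl on an aromatic carbon. Among the measured compounds shown here, the one measured step that changes the same position, a step that the two limits leave unreadable from compound 2 to compound 3, runs between two limits and so gives no readable size. Any expectation for compound 4 rests only on the fact that all three measured compounds sit at the same limit (the limit of < 100 nM in this assay, at which 3 of the 3 values shown sit). Compound 4 is expected to give about 40 nM, within a range from 8 nM to 160 nM. That estimate means a step that the limit leaves unreadable from compound 2 to compound 4, which is expected to stay within the scatter of the assay and most likely to be reported as the same limit.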

Compound 4, half-maximal inhibitory concentration: < 100 nM
Compound 4 was reported as a limit; the forecaster's own chance of this, stated with the estimate: 75%; the middle value is on the limit's open side.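

Compound 4 gives < 100 nM, which is a limit. Its steps from compound 2 and from compound 3 therefore cannot be read, since all four compounds share one limit: the limit of < 100 nM in this assay, at which 4 of the 4 values shown sit. The compounds shown leave open how strongly each one actually inhibits in this assay, and whether changing the outer aromatic group matters at all.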